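Aryl swap on the ring nitrogen of the shared core

This account rests on a few compounds, and the source may have more. Where it says the series, first, only, none or still open, it means among the compounds named here.

Going by the values given here, compound 2 `N#CC1=C(N)Oc2c(c3nc4ccccc4nc3c3ccccc23)C12C(=O)N(Cc1cnnn1-c1cccc(S(N)(=O)=O)c1)c1ccccc12` is the only member of the series with a number in a functional assay on HCT-116 cells (Homo sapiens) for antiproliferative activity, read by MTT assay, with a stated time of 48 h; on this read-out lower numbers stand for stronger inhibition and higher numbers for weaker inhibition: compound 2 gives 11300 nM. Compound 1 `COc1ccccc1-n1nncc1CN1C(=O)C2(C(C#N)=C(N)Oc3c2c2nc4ccccc4nc2c2ccccc32)c2ccccc21` reaches only a limit in this assay, where compound 1 gives > 50000 nM. Among the compounds with values here, the one measured step, an at least 4.4-fold lower number from compound 1 to compound 2 (0.64 log units; beyond the scatter), puts 3-sulfamoylphenyl where compound 1 carries 2-methoxyphenyl, and since the number of compound 1 is a limit of > 50000 nM in this assay, at which 1 of the 2 values shown sits, the step is known only as a lower bound. Compound 3 `Cc1ccc(-n2nncc2CN2C(=O)C3(C(C#N)=C(N)Oc4c3c3nc5ccccc5nc3c3ccccc43)c3ccccc32)c(C)c1` differs from compound 2 by 2,4-dimethylphenyl in place of 3-sulfamoylphenyl on an aromatic nitrogen. This runs against the direction of an at least 4.4-fold lower number from compound 1 to compound 2 (0.64 log units; beyond the scatter): an aryl group lacking the sulfamoyl group is present again, now as 2,4-dimethylphenyl. For compound 3 the expectation in this assay is therefore a step toward weaker inhibition, beyond the scatter, a 2.7-fold higher number from compound 2 to compound 3 (0.42 log units; beyond the scatter). Compound 3 is estimated at 30000 nM, in the range 10000 nM to 60000 nM, with a real chance that only a limit is reported.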

Compound 3, half-maximal inhibitory concentration: > 50000 nM
Compound 3: only a limit was reported; the forecaster's own chance of this, stated with the estimate: 40%; at least 1.6-fold (0.22 log units) between middle value and limit.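

On this aromatic nitrogen, 2,4-dimethylphenyl in place of 3-sulfamoylphenyl gives an at least 4.4-fold higher number from compound 2 to compound 3 (0.64 log units; beyond the scatter) in this assay, and this size is only a lower bound. With two different aryl groups lacking the sulfamoyl group now at the same place, the result for compound 2 no longer rests on its comparison with 2-methoxyphenyl alone. Compound 1 and compound 3 both stop at a limit, and the step joining them cannot be read: the limit of > 50000 nM in this assay, at which 2 of the 3 values shown sit.

Open, on these data alone, is whether the sulfamoyl group itself accounts for the difference, or whether a phenyl carrying a carboxylic acid or an amine in its place would also give a number rather than a limit. Also open, as far as these compounds go, is how the unsubstituted phenyl group would compare with compound 2 in this assay.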